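This account rests on a few compounds, and the source may have more. Where it says the series, first, only, none or still open, it means among the compounds named here.

Compound 2 `C=C(C)c1ccccc1OC(C)C1=NCCN1` gives the higher of the two numbers obtained so far in an assay on CHO cells for displacement of a labelled ligand from Alpha-2B adrenergic receptor (Homo sapiens) (on this read-out lower numbers stand for stronger inhibition and higher numbers for weaker inhibition), at 871 nM. Compound 1 `CCc1ccccc1OC(C)C1=NCCN1` gives 282 nM in this assay. For the measured compounds named here, the only measured step is a 3.1-fold higher number from compound 1 to compound 2 (0.49 log units; beyond the scatter), a modest move. Compound 3 `CCOc1ccccc1OC(C)C1=NCCN1` differs from compound 2 by ethoxy in place of 1-methylethenyl on an aromatic carbon. Going by the values given here, no measured step involves an ethoxy group, so the one step available bears only indirectly, and the direction of the new change is open. The expected step of a 1.9-fold lower number from compound 2 to compound 3 (0.29 log units; within the scatter) is accordingly kept small, with a wide range. Compound 3 is estimated at 450 nM, between 120 nM and 1700 nM.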

Compound 3, inhibition constant: 1320 nM
Beside the measured number, compound 3's estimate is 2.9-fold (0.47 log units) below it, within the range that was stated.
By their numbers in this assay, from the lowest: compound 1; then compounds 2 and 3 (each within the scatter of the next).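

On this aromatic carbon, ethoxy and 1-methylethenyl give numbers that stay within the scatter of each other in this assay (a 1.5-fold higher number from compound 2 to compound 3 (0.18 log units; within the scatter)), although ethoxy carries a hydrogen-bond acceptor and 1-methylethenyl none. Ethoxy in place of ethyl gives a second step beyond the scatter (a 4.7-fold higher number from compound 1 to compound 3 (0.67 log units; beyond the scatter)), so both replacements of ethyl raise the number, and compound 1 remains the strongest of the three. No evidence on the origin of these steps is at hand. The compounds shown leave open how methyl, methoxy, an amine or a longer chain such as propyl would read at this carbon.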